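A few compounds are considered here, and "the series" means these few. Any claim that something is new, unique, unknown or untested is made for them only; others in the source may bear on it.

Compound 1 `COc1ccc(-c2cc3ccccc3nc2C=O)cc1`: > 10000 nM
Compound 2 `COc1ccc(-c2cc3ccccc3nc2/C=C/C(=O)c2ccc(O)cc2)cc1`: 5690 nM
Compound 3 `COc1ccc(-c2cc3ccccc3nc2/C=C/C(=O)c2c(OC)cccc2OC)cc1`: 4470 nM
Compound 4 `COc1ccc(-c2cc3ccccc3nc2/C=C/C(=O)c2ccccn2)cc1`: not yet measured

In a functional assay on H184B5F5/M10 cells (Homo sapiens) for antiproliferative activity, read by XTT assay, with a stated time of 72 h (on this read-out lower numbers stand for stronger inhibition and higher numbers for weaker inhibition), compound 1 gives > 10000 nM, which is a limit of the assay and not a number. Compound 3 gives 4470 nM, within the scatter of compound 2 at 5690 nM. Compound 4 carries pyridin-2-yl in place of 2,6-dimethoxyphenyl on a carbonyl carbon. One measured step changes the group at this place: a 1.3-fold lower number from compound 2 to compound 3 (0.10 log units; within the scatter). That swap of 4-hydroxyphenyl for 2,6-dimethoxyphenyl left the number within the scatter, so no step beyond the scatter is expected here either, with an estimated 1.1-fold higher number from compound 3 to compound 4 (0.05 log units; within the scatter). Compound 4 is expected at 5000 nM, with an estimated range of 2000 nM to 10000 nM.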

Compound 4, half-maximal inhibitory concentration: 4140 nM
Beside the measured number, compound 4's estimate is 1.2-fold (0.08 log units) above it; measured number inside the range.
By their numbers in this assay, from the lowest: compounds 4, 3 and 2 (each within the scatter of the next). At a limit, above all of these: compound 1.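

In this assay, the group on the carbonyl carbon can now be a ring holding a nitrogen: pyridin-2-yl, smaller in heavy atoms than 2,6-dimethoxyphenyl, gives a result within the scatter, with a 1.1-fold lower number from compound 3 to compound 4 (0.03 log units; within the scatter). Set against 4-hydroxyphenyl, it also stays within the scatter, with a 1.4-fold lower number from compound 2 to compound 4 (0.14 log units; within the scatter). All three groups at this place therefore read alike so far. Nothing measured here accounts for this likeness. Going by these compounds, whether an amine, a carboxylic acid or a longer chain at this place would move the number beyond the scatter stays open.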